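A few compounds are considered here, and "the series" means these few. Any claim that something is new, unique, unknown or untested is made for them only; others in the source may bear on it.

Among the compounds with values here, in a functional assay on the whole organism for antagonist activity, with Mus musculus as the target (a higher number here means that more compound is needed for the effect, a lower number that less compound is needed), compound 1 `CCC(=O)N(c1ccc(Cl)c(Cl)c1)C1CCCC1O` gives 9 mg/kg, the lower of the two numbers known so far. Compound 2 `CCC(=O)N(c1ccc(C#N)cc1)C1CCCC1N(C)C` needs more, at 40 mg/kg, and this gap lies beyond the usual scatter. Compound 3 `CCC(=O)N(c1ccc(Cl)c(Cl)c1)C1CCCC1N` has not yet been measured in this assay. It keeps the core of compound 1 but carries amino in place of hydroxy on a saturated ring carbon. Within the data shown here, no measured pair shows this exchange, so the data offer no direct guide to the size of the step. Among the measured compounds shown here, the only anchor is compound 1 at 9 mg/kg, and a modest move toward a higher number is expected, perhaps not beyond the scatter. The expected step is a 1.7-fold higher number from compound 1 to compound 3 (0.22 log units; within the scatter). The estimated value for compound 3 is 15 mg/kg, within an expected range of 4 mg/kg to 60 mg/kg.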

Compound 3, dose for half-maximal effect: 0.8 mg/kg
Beside the measured number, compound 3's estimate is 19-fold (1.27 log units) above it, outside the stated range (below it).
By their numbers in this assay, from the lowest: compound 3; then compound 1; then compound 2.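

Exchanging hydroxy for amino on this saturated ring carbon brings an 11-fold lower number from compound 1 to compound 3 (1.05 log units; beyond the scatter) in this assay, so this position, next to the ring atom that bears a large group, is highly sensitive to which of these two groups it carries. The computed counts of heavy atoms, hydrogen-bond donors and acceptors and the net charge are the same for both groups, so these counts do not tell them apart, although the numbers differ widely. Nothing available here speaks to what lies behind this step.

The compounds shown leave open whether methylamino, aminomethyl or a carboxylic acid on this ring carbon would keep a number as low as that of compound 3. They also leave open whether the step carries over to another core, as compound 2 differs from compound 3 in more than one place.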